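The source may hold more compounds than are shown below. What is called first, only, known or untested is meant among the compounds shown, and "the series" means these compounds.

Compound 1 `C=C[C@@](C)(/C=C/c1ccc(Nc2ccc(OC)cc2)cc1)CCC=C(C)C`: > 52000 nM, a limit
Compound 2 `C=C[C@@](C)(/C=C/c1ccc(Nc2ccc(OC)c(F)c2)cc1)CCC=C(C)C`: > 52000 nM, a limit

In a functional assay on HepG2 cells (Homo sapiens) for cytotoxicity, with a stated time of 72 h (a lower number here means that less compound is needed, a higher number that more compound is needed for the effect), compound 2 gives > 52000 nM, which is a limit and not a number. Compound 1 gives > 52000 nM, which is also a limit. Compound 2 therefore has no exact value, and the evidence so far is the limit of > 52000 nM in this assay, at which 2 of the 2 values shown sit.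

The next compound, compound 3 `C=C[C@@](C)(/C=C/c1ccc(Nc2ccc(F)cc2)cc1)CCC=C(C)C`, has not yet been measured. It carries 4-fluorophenyl in place of 3-fluoro-4-methoxyphenyl on a nitrogen on an aromatic ring.

Among the compounds with values here, only one measured step bears on this change, and it is a different one: fluoro in place of hydrogen on an aromatic carbon. It is a step that the two limits leave unreadable from compound 1 to compound 2, so it offers no size to carry over. With no readable step as a guide, no shift beyond the usual scatter is expected in this assay, and no direction can be favoured. The expected step is a step that the limit leaves unreadable from compound 2 to compound 3. Compound 3 will most likely also be reported only as a limit. For compound 3 the estimated value is 60000 nM, with an expected range of 30000 nM to 120000 nM.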

Compound 3, half-maximal effective concentration: > 52000 nM
Compound 3: a limit, no number (the forecaster's own chance of this, stated with the estimate: 75%); the middle value does not contradict the limit.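

The steps among compound 1, compound 2 and compound 3 cannot be read, in size or in direction, and the picture is unchanged: the limit of > 52000 nM in this assay, at which 3 of the 3 values shown sit.

On these data alone, what stays open is how much of any of these three compounds would be needed for the effect in this assay, and whether their differing groups change that amount at all.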